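This account rests on a few compounds, and the source may have more. Where it says the series, first, only, none or still open, it means among the compounds named here.

Measured so far in a functional assay on MCF7 cells (Homo sapiens) for inhibition, with a stated time of 96 h (on this read-out higher numbers stand for weaker inhibition and lower numbers for stronger inhibition), are these:
Compound 1 `COc1cc(C(=O)c2cn(-c3cccc(C)c3)cc2-c2ccsc2)cc(OC)c1OC` gives 65 nM
Compound 2 `COc1cc(C(=O)c2cn(-c3ccc(C)cc3)cc2-c2ccoc2)cc(OC)c1OC` gives 18 nM
Compound 3 `COc1cc(C(=O)c2cn(-c3ccc(F)cc3)cc2-c2ccsc2)cc(OC)c1OC` gives 15 nM

Compound 3 sits at the low end of these numbers, within the scatter of compound 2 and clearly under compound 1. Compound 4 `COc1cc(C(=O)c2cn(-c3ccc(F)cc3)cc2-c2ccoc2)cc(OC)c1OC` differs from compound 3 by furan-3-yl in place of thiophen-3-yl on an aromatic carbon with furan-3-yl in place of thiophen-3-yl on an aromatic carbon. Among the measured compounds shown here, no measured step makes this swap alone. For the measured compounds named here, the one measured step of a 4.3-fold lower number from compound 1 to compound 3 (0.64 log units; beyond the scatter) changes the group on an aromatic nitrogen instead, so it bears only weakly here. Compound 2 already carries furan-3-yl and still gives 18 nM in this assay as a low number. No step beyond the scatter is therefore expected. The estimated step of a 1.2-fold higher number from compound 3 to compound 4 (0.08 log units; within the scatter) stays small. Compound 4 is expected at 18 nM with an estimated range from 7 nM to 45 nM overall.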

Compound 4, half-maximal inhibitory concentration: 15 nM
Compound 4: the middle estimate sits 1.2-fold (0.08 log units) above what was measured; low and high end bracket the measured number.
By their numbers in this assay, from the lowest: compounds 3, 4 and 2 (each within the scatter of the next); then compound 1.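

In this assay, among the compounds shown here, furan-3-yl in place of thiophen-3-yl on this aromatic carbon gives no change at the digits printed from compound 3 to compound 4 (within the scatter) and this is the first reading of that swap alone. With furan-3-yl held constant, fluoro in place of methyl gives a 1.2-fold lower number from compound 2 to compound 4 (0.08 log units; within the scatter) and so also stays inside the scatter. Nothing measured here explains why these compounds read alike. Going by these compounds, whether an amine, a carboxylic acid or a longer chain on this carbon would keep such numbers remains open. So does whether the swap reads the same with 3-methylphenyl on the ring nitrogen.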